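Phenyl to cyclopropyl on the ring nitrogen

The compounds below may be only part of what the source reports. "The series", "measured", "known", "first", "only" and "open" are said of these compounds alone.

In a functional assay on A-375 cells (Homo sapiens) for antiproliferative activity, read by MTT assay, with a stated time of 72 h (on this read-out higher numbers stand for weaker inhibition and lower numbers for stronger inhibition), compound 1 `COc1ncc(-c2ccc3c(c2)NC(=O)CO3)cc1NS(=O)(=O)c1ccc(F)cc1`, with hydrogen on the amide-type nitrogen, gives 26300 nM. Compound 2 `COc1ncc(-c2ccc3c(c2)N(C2CCCCC2)C(=O)CO3)cc1NS(=O)(=O)c1ccc(F)cc1`, with cyclohexyl there, is reported only as a limit, > 40000 nM. Compound 3 `COc1ncc(-c2ccc3c(c2)N(c2ccccc2)C(=O)CO3)cc1NS(=O)(=O)c1ccc(F)cc1`, with phenyl, gives 15200 nM. Against hydrogen, phenyl makes a 1.7-fold lower number from compound 1 to compound 3 (0.24 log units; within the scatter). Against cyclohexyl, it makes an at least 2.6-fold lower number from compound 2 to compound 3 (0.42 log units; beyond the scatter).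

Compound 4 `COc1ncc(-c2ccc3c(c2)N(C2CC2)C(=O)CO3)cc1NS(=O)(=O)c1ccc(F)cc1` differs from compound 3 in one group: cyclopropyl in place of phenyl on an amide-type nitrogen in a ring. Cyclopropyl is a non-aromatic ring, as is the cyclohexyl of compound 2, whose replacement of hydrogen gave an at least 1.5-fold higher number from compound 1 to compound 2 (0.18 log units; that floor lies within the scatter). A modest rise is therefore expected, about a 1.8-fold higher number from compound 3 to compound 4 (0.27 log units; within the scatter). For compound 4 the estimate is 28000 nM, with an expected range from 14000 nM to 48000 nM.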

Compound 4, half-maximal inhibitory concentration: 23900 nM
The estimate for compound 4 lay 1.2-fold (0.07 log units) above the measured number; low and high end bracket the measured number.
By their numbers in this assay, from the lowest: compounds 3, 4 and 1 (each within the scatter of the next). At a limit, above all of these: compound 2.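

In this assay cyclopropyl on this nitrogen sits level with phenyl (a 1.6-fold higher number from compound 3 to compound 4 (0.20 log units; within the scatter)) and with hydrogen (a 1.1-fold lower number from compound 1 to compound 4 (0.04 log units; within the scatter)). Neither the aromatic phenyl nor this small non-aromatic ring therefore stands apart from the unsubstituted compound 1. Compound 2 is reported only as a limit, and the step to cyclopropyl gives only a floor (an at least 1.6-fold lower number from compound 2 to compound 4 (0.22 log units; that floor lies within the scatter)), leaving that comparison unsettled: the limit of > 40000 nM in this assay, at which 1 of the 4 values shown sits.

Still open, as far as these compounds go, is whether a longer chain, or a chain ending in an amine or a carboxylic acid, on this nitrogen would move the number beyond the scatter.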